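Removing a methyl from a methoxy group: expected potency shift

This account rests on a few compounds, and the source may have more. Where it says the series, first, only, none or still open, it means among the compounds named here.

Of the compounds shown here, three built on one shared core have been tested in a functional assay on NCI-H520 cells (Homo sapiens) for cytotoxicity; a lower number here means a stronger inhibitor of growth, a higher number a weaker inhibitor of growth. Compound 1 `COc1ccc(C2=C(c3ccc(SC)cc3)CC3CCCN3C2=O)cc1O` gives 6000 nM. Compound 2 `COc1ccc(C2=C(c3ccc(SC)cc3)CC3CCCN3C2=O)cc1OC` gives 2000 nM, and compound 3 `COc1ccc(C2=C(c3ccc(SC)cc3)CC3CCCN3C2=O)cc1` gives 800 nM, the lowest number of the three. Compound 1 differs from compound 2 by hydrogen in place of methyl on an oxygen on an aromatic ring, a change that produced a 3.0-fold higher number from compound 2 to compound 1 (0.48 log units; beyond the scatter). The steps of a 7.5-fold lower number from compound 1 to compound 3 (0.88 log units; beyond the scatter) and a 2.5-fold lower number from compound 2 to compound 3 (0.40 log units; beyond the scatter) are likewise beyond the scatter.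

Compound 4 `CSc1ccc(C2=C(c3ccc(O)cc3)C(=O)N3CCCC3C2)cc1` has not yet been measured in this assay. Within the data shown here, it differs from compound 3 by hydrogen in place of methyl on an oxygen on an aromatic ring, which is the same change as the one from compound 2 to compound 1, at a place described in identical words. The cores of the two pairs differ: compound 3 differs from compound 2 by hydrogen in place of methoxy on an aromatic carbon. If the change behaves as it did before, compound 4 is expected to show a 3.0-fold higher number from compound 3 to compound 4 (0.48 log units; beyond the scatter), because a 3.0-fold higher number from compound 2 to compound 1 (0.48 log units; beyond the scatter) was seen when the methyl was removed on the other core. On that basis compound 4 is estimated at 2400 nM, with a plausible range from 1000 nM to 6000 nM.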

Compound 4, concentration for 50% growth inhibition: > 100000 nM
Compound 4: no number, only a limit (the forecaster's own chance of this, stated with the estimate: 5%); at least 41-fold (1.61 log units) between middle value and limit.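

In this assay compound 4 gives > 100000 nM, which is a limit of the assay and not a number. Replacing methyl with hydrogen on the oxygen raised the number on both cores, but the size of the rise did not carry over, with an at least 120-fold higher number from compound 3 to compound 4 (2.09 log units; beyond the scatter) and, against the other compound bearing a hydroxy group, an at least 16-fold higher number from compound 1 to compound 4 (1.22 log units; beyond the scatter), so the earlier step was a poor guide on this core: the same change on two cores in this assay, a 3.0-fold higher number (0.48 log units; beyond the scatter) from compound 2 to compound 1 and an at least 120-fold higher number (2.09 log units; beyond the scatter) from compound 3 to compound 4, at least 41-fold (1.61 log units) apart, beyond the scatter of two such steps. This shows that the change cannot be moved between these two cores at a fixed size, but it gives neither the true size of the new step, since only a limit is available, nor any reason for the gap, nor any rule for other cores.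

Going by these compounds, it remains open whether the loss is tied to the hydroxy group itself or would also appear with another group on the ring. An amine in place of the hydroxy, or ethoxy in place of the methoxy of compound 3, would help to separate these possibilities.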